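Working notes on the shared core: compound 3 toward compound 4

The source may hold more compounds than are shown below. What is called first, only, known or untested is meant among the compounds shown, and "the series" means these compounds.

Measured so far:
compound 1, `CCCCCCCCCCc1ccc(-c2noc(CN)n2)cc1`, 62%
compound 2, `CCCCCCCCCCc1ccc(-c2noc(CC3CNC3)n2)cc1`, 63%
compound 3, `CCCCCCCCCCc1ccc(-c2noc([C@@H]3CCC[C@@H](N)C3)n2)cc1`, 13%

In an assay on HeLa cells for inhibition of sphingosine-1-phosphate transporter SPNS2 (Mus musculus), read by LC-MS, tested at 2 uM (on this read-out lower numbers stand for less inhibition and higher numbers for more inhibition at the one concentration tested (going by the name of the read-out)), compound 3 stands lowest of the three numbers. Its nearest neighbour is compound 1, and the step of a number 49 percentage points lower from compound 1 to compound 3 (beyond the scatter) is large and beyond the scatter; the step of a number 50 percentage points lower from compound 2 to compound 3 (beyond the scatter) is of the same size. Compound 1 and compound 2 sit close together, with a number 1 percentage points higher from compound 1 to compound 2 (within the scatter) within the scatter, so the only clear movement in the set so far is the fall to compound 3, which carries the 3-aminocyclohexyl group on the aromatic carbon of the five-membered ring.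

Compound 4 is `CCCCCCCCCCc1ccc(-c2noc([C@H](N)CCCCN)n2)cc1`, not yet measured in this assay. It differs from compound 3 by 1,5-diaminopentyl in place of 3-aminocyclohexyl on an aromatic carbon. The ring leaves and an open chain with two amines enters at the same place on the core.

Both measured steps that end at compound 3 bear on this change, and both were large and downward into compound 3. Compound 4 carries no ring at that position, as compound 1 and compound 2 do not, so the expectation is that a good part of that drop is undone: a large step upward is expected in this assay, a number 32 percentage points higher from compound 3 to compound 4 (beyond the scatter). For compound 4 the expected value is therefore 45%, estimated to fall between 20% and 70%.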

Compound 4, a percentage reported as inhibition, at one concentration (the size of the read-out at that concentration, not a potency): 50%
For compound 4 the middle estimate is 5 percentage points below the measured one; the range from low to high includes it.
By their numbers in this assay, from the lowest: compound 3; then compound 4; then compounds 1 and 2 (each within the scatter of the next).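

In this assay, the fall seen with the 3-aminocyclohexyl group is not a fixed cost of a larger group at this aromatic carbon: with the count of heavy atoms unchanged, the open 1,5-diaminopentyl chain recovers much of the lost inhibition (a number 37 percentage points higher from compound 3 to compound 4 (beyond the scatter)). The recovery is only partial, since the new chain still stands modestly short of the (azetidin-3-yl)methyl group (a number 13 percentage points lower from compound 2 to compound 4 (beyond the scatter)), and adding 4-aminobutyl to the saturated chain carbon bound to the amine nitrogen and the aromatic carbon costs only a modest amount (a number 12 percentage points lower from compound 1 to compound 4 (beyond the scatter)). Nothing available explains these differences.

The compounds shown leave open whether the terminal amine of the 1,5-diaminopentyl group matters, which a plain pentyl chain or a hydroxyl at the chain end would test at this same position. They also leave open whether the low number belongs to the 3-aminocyclohexyl group alone or extends to other rings bound directly to this carbon, such as a 3-aminocyclopentyl or a piperidin-3-yl group.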